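This account rests on a few compounds, and the source may have more. Where it says the series, first, only, none or still open, it means among the compounds named here.

Compounds 1, 2 and 3 share one core and differ only in the group carried on the outer aromatic ring: compound 1 `N#Cc1ccc(Nc2cc3[nH]c(-c4cccc(C(F)(F)F)c4)nc3cn2)nc1` bears a cyano group, compound 2 `FC(F)(F)c1ccc(Nc2cc3[nH]c(-c4cccc(C(F)(F)F)c4)nc3cn2)nc1` a trifluoromethyl group, and compound 3 `O=C(O)c1ccc(Nc2cc3[nH]c(-c4cccc(C(F)(F)F)c4)nc3cn2)nc1` a carboxy group. In a physicochemical assay for solubility, using the shake flask method, in simulated intestinal fluid, measured as kinetic solubility, with a stated time of 20 h, at pH 6.5 (a higher number here means a more soluble compound, a lower number a less soluble compound), compound 1 gives >= 50000 nM, which is a limit of the assay rather than a number. Compound 2 likewise gives >= 50000 nM, also a limit. Among the measured compounds shown here, compound 3 gives 6000 nM, the only plain number of the three, and it stands lowest; the readings of the other two sit at the limit of >= 50000 nM in this assay, at which 2 of the 3 values shown sit. The steps of an at least 8.3-fold lower number from compound 1 to compound 3 (0.92 log units; beyond the scatter) and an at least 8.3-fold lower number from compound 2 to compound 3 (0.92 log units; beyond the scatter) both touch this same position.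

Compound 4 `NC(=O)c1ccc(Nc2cc3[nH]c(-c4cccc(C(F)(F)F)c4)nc3cn2)nc1` again changes that position: amino in place of hydroxy on a carbonyl carbon. Since both measured changes away from carboxy went with higher readings, an upward step a 3.3-fold higher number from compound 3 to compound 4 (0.52 log units; beyond the scatter) is expected. Compound 4 is therefore estimated at 20000 nM, between 5000 nM and 60000 nM.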

Compound 4, solubility: < 5000 nM
Compound 4 gave a limit, no number; the forecaster's own chance of this, stated with the estimate: 30%; at least 4.0-fold (0.60 log units) between middle value and limit.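

Putting carbamoyl in place of trifluoromethyl or cyano lowers the reading, as carboxy did, with an at least 10-fold lower number from compound 2 to compound 4 (1.00 log units; beyond the scatter) and an at least 10-fold lower number from compound 1 to compound 4 (1.00 log units; beyond the scatter). Set against carboxy itself, the swap of hydroxy for amino gives an at least 1.2-fold lower number from compound 3 to compound 4 (0.07 log units; that floor lies within the scatter), so these two groups cannot be separated here. The reading of compound 4 is a limit of the assay, not a number: the limit of < 5000 nM in this assay, at which 1 of the 4 values shown sits.

As far as these compounds go, the true size of every step to compound 4 stays unknown. From the compounds shown here alone, it is also open whether a methyl ester or a primary amine at this position would read low, like carboxy and carbamoyl, or high, like cyano and trifluoromethyl.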